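This account rests on a few compounds, and the source may have more. Where it says the series, first, only, none or still open, it means among the compounds named here.

In a functional assay on PC-3 cells (Homo sapiens) for antiproliferative activity, read by MTT assay, with a stated time of 48 h (a higher number here means a weaker inhibitor, a lower number a stronger inhibitor), compound 2 `COc1ccc(/C=C/C(=O)Nc2cc3c(Nc4ccc(Cl)c(Cl)c4)ncnc3s2)cc1` gives 790 nM. This lies within the scatter of compound 1 `C#Cc1cccc(Nc2ncnc3cc(NC(=O)/C=C/c4ccccc4)sc23)c1` at 700 nM and compound 3 `N#Cc1cccc(Nc2ncnc3cc(NC(=O)/C=C/c4ccccc4)sc23)c1` at 540 nM. Compound 4 `O=C(/C=C/c1ccccc1)Nc1cc2c(Nc3ccc(Cl)c(Cl)c3)ncnc2s1` has hydrogen in place of methoxy on an aromatic carbon of compound 2: hydrogen in place of methoxy on an aromatic carbon. Among the measured compounds shown here, no measured step makes this change. For the measured compounds named here, the only step available, a 1.3-fold lower number from compound 1 to compound 3 (0.11 log units; within the scatter), puts cyano in place of ethynyl and stays within the scatter. Compound 1, at 700 nM, already carries the 2-phenylethenyl group of compound 4, though the rest of the molecule differs. No shift beyond the scatter is therefore expected. The estimated step is a 1.1-fold lower number from compound 2 to compound 4 (0.05 log units; within the scatter). For compound 4 the estimated value is 700 nM, with an expected range from 300 nM to 1600 nM.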

Compound 4, half-maximal inhibitory concentration: 480 nM
Compound 4: the middle estimate sits 1.5-fold (0.16 log units) above what was measured, within the range that was stated.
By their numbers in this assay, from the lowest: compounds 4, 3, 1 and 2 (each within the scatter of the next).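

In this assay the change from 4-methoxyphenyl to phenyl can now be read directly (a 1.6-fold lower number from compound 2 to compound 4 (0.22 log units; within the scatter)). On this aromatic carbon, para to a large group, hydrogen and methoxy therefore give numbers that cannot be told apart, which the earlier step, a change at a different place, could not show. Nothing available explains this result. From the compounds shown here alone, whether a different group here, such as an amine, a carboxylic acid or a longer chain, would shift the number beyond the scatter stays open.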